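This account rests on a few compounds, and the source may have more. Where it says the series, first, only, none or still open, it means among the compounds named here.

Values in a functional assay on CNE-2 cells (Homo sapiens) for inhibition, read by MTT assay, with a stated time of 72 h; a lower number here means a stronger inhibitor, a higher number a weaker inhibitor:
- compound 1 `Nc1nc2cc(-c3nn(CCCCCCCCCC(=O)NO)c4ncnc(N)c34)ccc2o1`: 36800 nM
- compound 2 `Nc1nc2cc(-c3nn(CCC(=O)NO)c4ncnc(N)c34)ccc2o1`: > 150000 nM (a limit, not a number)
- compound 3 `Nc1nc2cc(-c3nn(CCCCCCCCC(=O)NO)c4ncnc(N)c34)ccc2o1`: 3240 nM

Compound 2 has no exact value and stands only at a limit: the limit of > 150000 nM in this assay, at which 1 of the 3 values shown sits.

Compound 4 `Nc1nc2cc(-c3nn(CC(=O)NO)c4ncnc(N)c34)ccc2o1` has not yet been measured. The change from compound 2 is hydroxycarbamoyl in place of (hydroxycarbamoyl)methyl on a saturated chain carbon bound to an aromatic nitrogen. In words, it is hydroxycarbamoyl in place of (hydroxycarbamoyl)methyl on a saturated chain carbon bound to an aromatic nitrogen.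

Among the compounds with values here, no measured step covers this short end of the chain directly. The nearest evidence is an at least 46-fold lower number from compound 2 to compound 3 (1.66 log units; beyond the scatter), together with an at least 4.0-fold higher number from compound 1 to compound 2 (0.61 log units; beyond the scatter). Both are bounded on one side by the limit, and both tie the short chain of compound 2 to a high number. The step of an 11-fold lower number from compound 1 to compound 3 (1.06 log units; beyond the scatter) is the same change in words, made far out on a long chain, and it lowered the number. Compound 1 thus goes against any simple rule that a longer chain gives a lower number, and that step cannot be carried over to this end of the series.

Since an at least 46-fold lower number from compound 2 to compound 3 (1.66 log units; beyond the scatter) sets the short chain far from compound 3, no gain is expected in this assay, and no change beyond the scatter. The expected size is a number no higher from compound 2 to compound 4 (the limit leaves the size open). A second report as a limit is quite likely. The estimate for compound 4 is 150000 nM, with an expected range of 50000 nM to 400000 nM.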

Compound 4, half-maximal inhibitory concentration: 12200 nM
Compound 4: the middle estimate sits 12-fold (1.09 log units) above what was measured; the whole stated range lies above it.
By their numbers in this assay, from the lowest: compound 3; then compound 4; then compound 1. At a limit, above all of these: compound 2.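

In this assay, the change at this position, hydroxycarbamoyl in place of (hydroxycarbamoyl)methyl on a saturated chain carbon bound to an aromatic nitrogen, gives an at least 12-fold lower number from compound 2 to compound 4 (1.08 log units; beyond the scatter), so a short chain on the shared core does not by itself go with a high number. Compound 2 stands only at a limit, > 150000 nM, and not at an exact number. Across the four compounds the number follows no single direction with chain length: a longer chain gives a lower number from compound 2 to compound 3, but compound 1 and compound 2 each go against that rule, and the same change in words lowered the number at both the long and the short end of the series: the same change on two cores in this assay, an 11-fold lower number (1.06 log units; beyond the scatter) from compound 1 to compound 3 and an at least 12-fold lower number (1.08 log units; beyond the scatter) from compound 2 to compound 4; the limit leaves it open whether they differ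

Open, on these data alone, is how the number runs for chains of intermediate length between those of compound 2 and compound 3, so four compounds cannot show whether the chain of compound 3 is a single low point. Also open, as far as these compounds go, is how far these numbers depend on the hydroxycarbamoyl end, a question that a carboxylic acid at the chain end on the shared core would address.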